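Swapping the Benzyl Cap for Quinolinyl in a Hydroxamate

The source may hold more compounds than are shown below. What is called first, only, known or untested is meant among the compounds shown, and "the series" means these compounds.

Measured compounds, each with its result in a functional assay on MM96L cells (Homo sapiens) for antiproliferative activity; a lower number here means a stronger inhibitor, a higher number a weaker inhibitor:
compound 1 `CN(C)c1ccc(C(=O)N[C@@H](CCCCCC(=O)NO)C(=O)NCc2ccccc2)cc1` gives 1600 nM
compound 2 `O=C(/C=C/c1ccccc1)N[C@@H](CCCCCC(=O)NO)C(=O)NCc1ccccc1` gives 460 nM
compound 3 `O=C(CCCCC[C@H](NC(=O)c1ccc(C(F)(F)F)cc1)C(=O)NCc1ccccc1)NO` gives 660 nM

All three share a core carrying a hydroxamic acid and two amide arms; they differ only in the group on one of the amide carbonyls. Compound 2 has the lowest number of the three. Its gap to compound 3 is a 1.4-fold higher number from compound 2 to compound 3 (0.16 log units; within the scatter), so those two cannot be told apart, while compound 1 stands clearly apart, as a 3.5-fold lower number from compound 1 to compound 2 (0.54 log units; beyond the scatter) shows.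

Compound 4 `O=C(/C=C/c1ccccc1)N[C@@H](CCCCCC(=O)NO)C(=O)Nc1cccc2cccnc12` keeps the 2-phenylethenyl arm of compound 2 and changes the other amide: quinolin-8-yl in place of benzyl on an amide-type nitrogen. Going by the values given here, none of the measured steps touches this amide nitrogen; every one of them, a 3.5-fold lower number from compound 1 to compound 2 (0.54 log units; beyond the scatter), a 2.4-fold lower number from compound 1 to compound 3 (0.38 log units; beyond the scatter) and a 1.4-fold higher number from compound 2 to compound 3 (0.16 log units; within the scatter), concerns the carbonyl arm. The data therefore give no direct guide to the size or direction of this change. In the absence of any bearing step, the expectation is that compound 4 will show a step of a 1.1-fold higher number from compound 2 to compound 4 (0.04 log units; within the scatter), with a wide range to reflect the uncertainty. Compound 4 is estimated at 500 nM, expected to fall between 150 nM and 1700 nM.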

Compound 4, half-maximal inhibitory concentration: 21 nM
Estimate against measurement, compound 4: 24-fold (1.38 log units) above; the measured number lies below the stated range.
By their numbers in this assay, from the lowest: compound 4; then compounds 2 and 3 (each within the scatter of the next); then compound 1.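

Quinolin-8-yl in place of benzyl on the amide-type nitrogen gives a 22-fold lower number from compound 2 to compound 4 (1.34 log units; beyond the scatter) in this assay and is a larger step than any of those among compounds 1, 2 and 3, all of which concern the carbonyl arm. Going by these compounds alone, this shows that the amide nitrogen, which the earlier compounds left unchanged, is a position where a single change can shift the number strongly. The new group has a six-membered aromatic ring with a ring nitrogen and a hydrogen-bond acceptor that benzyl lacks, but no measurement is available to explain why this exchange has such a large effect.

The compounds shown leave open whether the ring nitrogen of quinolin-8-yl is needed, which a naphthyl group, built of carbon only, could test in the same place. They also leave open whether the large step carries over when quinolin-8-yl is paired with the 4-(trifluoromethyl)phenyl arm of compound 3 or the 4-(dimethylamino)phenyl arm of compound 1, and how a longer chain leading to the hydroxamic acid would behave.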